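This account rests on a few compounds, and the source may have more. Where it says the series, first, only, none or still open, it means among the compounds named here.

The study concerns a set of nucleoside analogues tested in a functional assay on G-361 cells (Homo sapiens) for antiproliferative activity, with a stated time of 72 h; a lower number here means a stronger inhibitor, a higher number a weaker inhibitor. Compound 1, `OC[C@H]1O[C@@H](n2cnc3c(NCc4ccc(Cl)cc4)ncnc32)[C@H](O)[C@@H]1O`, carries a 4-chlorobenzyl group on the amine of the shared core. In this assay compound 1 gives only a limit, > 166000 nM, not a number. Compound 2, `COc1cccc(CNc2ncnc3c2ncn3[C@@H]2O[C@H](CO)[C@@H](O)[C@H]2O)c1OC`, carries a 2,3-dimethoxyphenyl group on the saturated chain carbon bound to a nitrogen on the aromatic ring; in this assay compound 2 has no result, "not determined" (no result reported). Compound 3, `COc1ccc(CNc2ncnc3c2ncn3C2OC(CO)[C@@H](O)[C@H]2O)c(O)c1`, likewise has no result in this assay, "not determined" (no result reported). Thus compound 2 stands nowhere on the numbers shown: the only value in the whole set is a limit, and among the three entries shown the rest are empty.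

Compound 4, `OC[C@H]1O[C@@H](n2cnc3c(NCc4ccccc4OC(F)F)ncnc32)[C@H](O)[C@@H]1O`, has not yet been measured. Its difference from compound 2 is 2-(difluoromethoxy)phenyl in place of 2,3-dimethoxyphenyl on a saturated chain carbon bound to a nitrogen on an aromatic ring. Going by the values given here, no step between measured compounds exists here, so the size and direction of the change from compound 2 to compound 4 in this assay cannot be read from the data; the only anchor is the evidence that (the limit of > 166000 nM in this assay, at which 1 of the 3 values shown sits). In this assay compound 4 is expected to remain a weak inhibitor, around 100000 nM, with a range from 20000 nM to 300000 nM.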

Compound 4, half-maximal inhibitory concentration: > 166000 nM
Compound 4 ended at the assay's limit; the forecaster's own chance of this, stated with the estimate: 60%; middle value at least 1.6-fold (0.22 log units) away from the limit.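

Compound 1 and compound 4 both end at a limit of this assay, not at a number, so no step between them can be read: the limit of > 166000 nM in this assay, at which 2 of the 4 values shown sit.

The compounds shown leave open whether 2-(difluoromethoxy)phenyl in place of 4-chlorophenyl changes activity at all, and how any group on the shared core would rank in this assay.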